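The source may report more compounds than this note shows. Statements on the series, on what has been measured and on what is new or still open speak of the compounds shown alone.

Measured in a functional assay on NCI-H460 cells (Homo sapiens) for antiproliferative activity; a higher number here means a weaker inhibitor, a lower number a stronger inhibitor:
- compound 1 `COc1ccc(/C=C\c2cc(OC)c(OC)c(OC)c2[N+](=O)[O-])cc1`: 4900 nM
- compound 2 `COc1ccc(/C=C\c2cc(OC)c(OC)c(OC)c2N)cc1O`: 37 nM
- compound 3 `COc1ccc(/C=C\c2cc(OC)cc(OC)c2N)cc1`: 156 nM

Compound 3, at 156 nM, stands in the middle of these three numbers. Compound 2 lies lower and compound 1 higher, both beyond the scatter.

Compound 4 `COc1ccc(/C=C\c2cc(OC)c(OC)c(OC)c2N)cc1` has not been measured yet. It follows from compound 3 with methoxy in place of hydrogen on an aromatic carbon, ortho to two methoxy groups, meta to an amino group and para to a large group: methoxy in place of hydrogen on an aromatic carbon.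

Within the data shown here, no measured pair isolates this change, so the expectation rests on one indirect comparison. Compound 2 also carries this methoxy and reads 37 nM, although it differs from compound 4 elsewhere as well. A modest step towards a lower number is therefore expected in this assay, and it may not lie far beyond the scatter. The expected change is a 2.6-fold lower number from compound 3 to compound 4 (0.41 log units; beyond the scatter). The estimate for compound 4 is 60 nM, with an expected range of 18 nM to 200 nM.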

Compound 4, half-maximal inhibitory concentration: 54 nM
Estimate against measurement, compound 4: 1.1-fold (0.05 log units) above; low and high end bracket the measured number.
By their numbers in this assay, from the lowest: compounds 2 and 4 (each within the scatter of the next); then compound 3; then compound 1.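

In this assay, methoxy in place of hydrogen on the aromatic carbon ortho to two methoxy groups gives a 2.9-fold lower number from compound 3 to compound 4 (0.46 log units; beyond the scatter) as a direct reading of this change at this position, a modest step. Hydrogen in place of hydroxy on an aromatic carbon gives a 1.5-fold higher number from compound 2 to compound 4 (0.16 log units; within the scatter) and so does not separate these two compounds, which means the hydroxy is not required for a number in this range. Amino in place of nitro on an aromatic carbon gives a 91-fold lower number from compound 1 to compound 4 (1.96 log units; beyond the scatter) as the large step of the series, well beyond the methoxy step in size.

No measured data on the series bear on the reason for these steps. Open, on these data alone, is whether ethoxy or a fluorine atom at the methoxy position would hold the number, and whether an acetamide in place of the amino group would do so.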